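A few compounds are considered here, and "the series" means these few. Any claim that something is new, unique, unknown or untested is made for them only; others in the source may bear on it.

Compound 2 `Cn1c(=O)c(C(=O)Nc2ccc(Oc3ccncc3-c3cccnc3)c(F)c2)nn(-c2ccccc2F)c1=O` is one of two compounds tested in a functional assay on MDA-MB-231 cells (Homo sapiens) for cytotoxicity, read by MTT assay, with a stated time of 72 h (on this read-out lower numbers stand for stronger inhibition and higher numbers for weaker inhibition), where compound 2 gives 6760 nM. Compound 1 `Fc1ccc(Nc2cc(Nc3ccc(Oc4ccncc4-c4cccnc4)c(F)c3)ncn2)cc1F` gives 6770 nM in this assay, a value that sits within the usual scatter of that of compound 2, so the two cannot be told apart. Compound 3 `Cn1c(=O)c(C(=O)Nc2ccc(Oc3ccncc3-c3cccnc3)c(F)c2)nn(-c2c(Cl)cccc2Cl)c1=O` has not yet been measured; it differs from compound 2 by 2,6-dichlorophenyl in place of 2-fluorophenyl on an aromatic nitrogen. Among the measured compounds shown here, with no measured step of this kind to draw on, the step from compound 2 to compound 3 is expected to be small, likely no larger than the scatter, and the author estimates it as a 1.1-fold lower number from compound 2 to compound 3 (0.05 log units; within the scatter). Compound 3 is thus expected to give about 6000 nM, with a range of 2500 nM to 15000 nM.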

Compound 3, half-maximal inhibitory concentration: 9690 nM
Estimate against measurement, compound 3: 1.6-fold (0.21 log units) below, within the range that was stated.
By their numbers in this assay, from the lowest: compounds 2, 1 and 3 (each within the scatter of the next).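

Among the compounds shown here, the exchange of 2-fluorophenyl for 2,6-dichlorophenyl on the aromatic nitrogen comes with a 1.4-fold higher number from compound 2 to compound 3 (0.16 log units; within the scatter) in this assay and gives the first reading at this position. Here one halogen-bearing phenyl group stands in for another with no change that can be told from the scatter, which compounds 1 and 2, differing in more than one place, could not show. Nothing at hand offers an explanation for this step. Still open, from the compounds shown here alone, is whether an unsubstituted phenyl, a cyclohexyl or an aminoalkyl chain on this nitrogen would leave the number equally unchanged.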